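This account rests on a few compounds, and the source may have more. Where it says the series, first, only, none or still open, it means among the compounds named here.

Three analogues of one core, differing only in the aryl group carried on an aromatic nitrogen, have been read in a functional assay on DU-145 cells (Homo sapiens) for antiproliferative activity, read by MTT assay, with a stated time of 48 h; on this read-out higher numbers stand for weaker inhibition and lower numbers for stronger inhibition. Compound 1 `C/C(=C\CC/C(C)=C/CC[C@@H]1[C@@]2(C)CCC(=O)C(C)(C)[C@H]2CC[C@@]1(C)O)CC/C=C(\C)C(=O)OCc1cn(-c2ccccc2Cl)nn1` reaches only a limit in this assay, giving > 150000 nM. Compound 2 `C/C(=C\CC/C(C)=C/CC[C@@H]1[C@@]2(C)CCC(=O)C(C)(C)[C@H]2CC[C@@]1(C)O)CC/C=C(\C)C(=O)OCc1cn(-c2ccccc2)nn1` gives 95500 nM in this assay. Compound 3 `C/C(=C\CC/C(C)=C/CC[C@@H]1[C@@]2(C)CCC(=O)C(C)(C)[C@H]2CC[C@@]1(C)O)CC/C=C(\C)C(=O)OCc1cn(-c2ccc(F)c(Cl)c2)nn1` likewise returns only a limit in this assay, namely > 150000 nM. Compound 3 thus sits at the top of the measurable range: the step that the two limits leave unreadable from compound 1 to compound 3 cannot be read, while an at least 1.5-fold lower number from compound 1 to compound 2 (0.19 log units; that floor lies within the scatter) and an at least 1.5-fold higher number from compound 2 to compound 3 (0.19 log units; that floor lies within the scatter) each rest on a floor that lies within the scatter, and the limit of > 150000 nM in this assay, at which 2 of the 3 values shown sit, marks the position shared by compound 3. Compound 4 `C/C(=C\CC/C(C)=C/CC[C@@H]1[C@@]2(C)CCC(=O)C(C)(C)[C@H]2CC[C@@]1(C)O)CC/C=C(\C)C(=O)OCc1cn(-c2ccccc2[N+](=O)[O-])nn1` is the next member: 2-nitrophenyl in place of 3-chloro-4-fluorophenyl on an aromatic nitrogen. Within the data shown here, no measured step involves a nitro group; the only readable steps concern hydrogen for chloro and 3-chloro-4-fluorophenyl for phenyl, both floored within the scatter. No change beyond the scatter is therefore expected for compound 4 in this assay, the weak activity of the whole set being the guide. For compound 4 the estimate in this assay is 140000 nM, within 60000 nM to 300000 nM. The step expected is an at least 1.0-fold lower number from compound 3 to compound 4 (0.02 log units; that floor lies within the scatter), and a limit rather than a number is the likelier outcome.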

Compound 4, half-maximal inhibitory concentration: > 150000 nM
Compound 4 gave a limit, no number; the forecaster's own chance of this, stated with the estimate: 60%; middle value at least 1.0-fold (0.02 log units) from the limit.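

In this assay compound 4 also ends at a limit, > 150000 nM, which is not a number, so a 2-nitrophenyl group on the aromatic nitrogen gives no readable value here, just as the two halogenated aryl groups did. Nitro in place of hydrogen gives an at least 1.5-fold higher number from compound 2 to compound 4 (0.19 log units; that floor lies within the scatter), so this comparison with the unsubstituted phenyl group also shows no change beyond the scatter. The steps linking compound 4 to compound 1 and compound 3 cannot be read, and the set now gathers at one point: the limit of > 150000 nM in this assay, at which 3 of the 4 values shown sit.

Among these compounds, whether any substituent on this aryl group truly moves the read-out stays open, and compound 2 remains the only member with a number, 95500 nM. Also open, on these data alone, is whether an amine or a carboxylic acid on the phenyl ring would return a number rather than a limit.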